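A few compounds are considered here, and "the series" means these few. Any claim that something is new, unique, unknown or untested is made for them only; others in the source may bear on it.

Compound 1 `C=CCn1c(=O)/c(=C\c2cccc(F)c2)[nH]c(=O)/c1=C\c1ccccc1OC` gives 5600 nM
Compound 2 `C=CCn1c(=O)/c(=C\c2ccccc2OC)[nH]c(=O)/c1=C\c1ccccc1OC` gives 13400 nM
Compound 3 `C=CCn1c(=O)/c(=C\c2cccc(Br)c2)[nH]c(=O)/c1=C\c1ccccc1OC` gives 5900 nM

These three compounds share one core and were tested in a functional assay on BGC-823 cells (Homo sapiens) for cytotoxicity, read by CCK-8 assay, with a stated time of 72 h; on this read-out higher numbers stand for weaker inhibition and lower numbers for stronger inhibition. Among the three numbers, compound 3 stands second highest. Its nearest neighbour is compound 1: the step of a 1.1-fold higher number from compound 1 to compound 3 (0.02 log units; within the scatter) is too small to count. The furthest is compound 2, and the step of a 2.3-fold lower number from compound 2 to compound 3 (0.36 log units; beyond the scatter) shows a modest gain when 2-methoxyphenyl is exchanged for 3-bromophenyl.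

Compound 4 `C=CCn1c(=O)/c(=C\c2ccc(C)cc2)[nH]c(=O)/c1=C\c1ccccc1OC` has not yet been measured. It differs from compound 3 in one place: 4-methylphenyl in place of 3-bromophenyl on a double-bonded chain carbon bound to an aromatic carbon. Within the data shown here, no measured step puts a 4-methylphenyl on this carbon, so the evidence is indirect. The two measured changes at this place, a 2.4-fold higher number from compound 1 to compound 2 (0.38 log units; beyond the scatter) and a 2.3-fold lower number from compound 2 to compound 3 (0.36 log units; beyond the scatter), were both modest, and the swap of one halogen for another, a 1.1-fold higher number from compound 1 to compound 3 (0.02 log units; within the scatter), stayed within the scatter. A modest step in this assay, more likely towards a higher number than a lower one, is therefore expected, because compound 2 gives 13400 nM as the only variant here without a halogen. Compound 4 is expected to give about 8000 nM, within a range from 3500 nM to 18000 nM. That estimate means an expected step of a 1.4-fold higher number from compound 3 to compound 4 (0.13 log units; within the scatter).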

Compound 4, half-maximal inhibitory concentration: "not active" (no number reported)
Compound 4: no number reported; the estimate stays without a comparison.
By their numbers in this assay, from the lowest: compounds 1 and 3 (each within the scatter of the next); then compound 2.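

Among these compounds, compound 4 is reported as "not active" without a number, so no step from compound 3 to compound 4 can be read. Nothing given here accounts for this result. The compounds shown leave open how far 4-methylphenyl in place of 3-bromophenyl changes the number, if it can be put in numbers at all.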